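A few compounds are considered here, and "the series" means these few. Any claim that something is new, unique, unknown or untested is made for them only; others in the source may bear on it.

Compound 2 `CCCCc1cn(C[C@H](O)[C@H]2OC(=O)C(OCc3ccccc3)=C2OCc2ccccc2)nn1`: 26300 nM
Compound 1 `O=C1O/C(=C\Cn2cc(-c3ccc(Br)cc3)nn2)C(OCc2ccccc2)=C1OCc1ccccc1`: > 100000 nM

Among the measured compounds shown here, in an ADME assay on HFF cells (Homo sapiens) for cytotoxicity, read by MTT assay, with a stated time of 72 h (a lower number here means a stronger inhibitor, a higher number a weaker inhibitor), compound 2 gives 26300 nM, the only number among the two measured compounds. Compound 1 sits at the limit of > 100000 nM in this assay, at which 1 of the 2 values shown sits, which is a limit of the assay and not a number. For the measured compounds named here, no step between measured compounds is known. Compound 3 `O=C1O[C@H]([C@@H](O)Cn2cc(-c3cc(F)cc(F)c3)nn2)C(OCc2ccccc2)=C1OCc1ccccc1` differs from compound 2 by 3,5-difluorophenyl in place of butyl on an aromatic carbon. With compound 1 standing at the limit of > 100000 nM in this assay, at which 1 of the 2 values shown sits, the step in this assay is expected to run toward weaker inhibition and beyond the scatter. The expected step is a 2.1-fold higher number from compound 2 to compound 3 (0.32 log units; beyond the scatter). Compound 3 is estimated at 55000 nM, with a range from 15000 nM to 150000 nM.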

Compound 3, half-maximal inhibitory concentration: > 100000 nM
Compound 3: a limit, no number; the forecaster's own chance of this, stated with the estimate: 35%; middle value at least 1.8-fold (0.25 log units) away from the limit.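

In this assay, among the compounds shown here, 3,5-difluorophenyl in place of butyl on the aromatic carbon gives an at least 3.8-fold higher number from compound 2 to compound 3 (0.58 log units; beyond the scatter), the first evidence that a change at this position moves the read-out, here toward weaker inhibition. On these data alone, the true size of this step stays unknown, as the value of compound 3 is a limit of the assay and not a number. Only compound 2 gives a number, and the other compounds sit at the top of the range: the limit of > 100000 nM in this assay, at which 2 of the 3 values shown sit.

The compounds shown leave open whether a longer chain, an unsubstituted phenyl or an amine at this position would give a number. They also leave open how the fluorines alone contribute.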